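The source may hold more compounds than are shown below. What is called first, only, known or untested is meant among the compounds shown, and "the series" means these compounds.

Measured so far:
Compound 1 `O=C(Nc1ccc(Cl)c(-c2nnc3c(Cl)cccn23)c1)c1ccc(C(F)(F)F)cc1Cl`: > 100000 nM
Compound 2 `O=C(Nc1ccc(Cl)c(-c2nnc3c(Cl)cccn23)c1)c1cccnc1`: > 100000 nM
Compound 3 `O=C(Nc1ccc(Cl)c(-c2nnc3c(Cl)cccn23)c1)c1ccc(C(F)(F)F)cc1F`: 41200 nM

These three share one core and differ only in the group attached to the carbonyl carbon. In a functional assay on AN3-CA cells (Homo sapiens) for antiproliferative activity, read by MTT assay, with a stated time of 72 h (on this read-out higher numbers stand for weaker inhibition and lower numbers for stronger inhibition), compound 2 reaches only a limit of the assay, > 100000 nM, not a number. Compound 1 likewise sits at a limit in this assay, > 100000 nM. Compound 3 gives a number in this assay, 41200 nM. Going by the values given here, the single measured step, an at least 2.4-fold lower number from compound 1 to compound 3 (0.38 log units; beyond the scatter), concerns a halogen exchange and does not touch the change considered here. Compound 4 `CS(=O)(=O)c1ccc(C(=O)Nc2ccc(Cl)c(-c3nnc4c(Cl)cccn34)c2)cc1` arises from compound 2 by 4-(methylsulfonyl)phenyl in place of pyridin-3-yl on a carbonyl carbon. Among the compounds with values here, no measured step bears on this exchange; with the limit of > 100000 nM in this assay, at which 2 of the 3 values shown sit, marking where two of the three values sit, a large shift in this assay is not expected. Compound 4 is estimated at 80000 nM, between 20000 nM and 300000 nM. The expected step is an at least 1.2-fold lower number from compound 2 to compound 4 (0.09 log units; that floor lies within the scatter).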

Compound 4, half-maximal inhibitory concentration: > 100000 nM
Compound 4: only a limit was reported; the forecaster's own chance of this, stated with the estimate: 55%; middle value at least 1.2-fold (0.09 log units) away from the limit.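

In this assay, compound 2 and compound 4 both give only a limit, not a number, and the step between them cannot be read. The compounds shown leave open whether 4-(methylsulfonyl)phenyl in place of pyridin-3-yl changes activity at all, with most values resting at one limit: the limit of > 100000 nM in this assay, at which 3 of the 4 values shown sit.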